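The compounds below may be only part of what the source reports. "The series", "measured", "known", "first", "only" and "open" are said of these compounds alone.

Within the data shown here, compound 1, with the structure `Cc1ccc2c(=O)cc(-c3ccc(F)cc3)oc2c1`, is one of two compounds measured here. In an in vitro assay on BTI-TN-5B1-4 cells for inhibition of Amine oxidase [flavin-containing] B (Homo sapiens), tested at 100 uM (a lower number here means less inhibition, a higher number more inhibition at the concentration tested (going by the name of the read-out)), compound 1 gives 40%. Among the measured compounds shown here, compound 2, with the structure `Cc1ccc2c(=S)cc(-c3ccccc3)oc2c1`, differs from compound 1 in two places at once, so no single step connects them; in this assay compound 2 gives 40%, which is level with compound 1 within the usual scatter of such measurements.

Compound 3, with the structure `S=c1cc(-c2ccccc2)oc2ccccc12`, has not yet been measured. Compared with compound 2, the change is small: hydrogen in place of methyl on an aromatic carbon. For the measured compounds named here, no measured pair in this set isolates the loss of a methyl group, so there is nothing to lean on. The expectation is that the step of a number 2 percentage points lower from compound 2 to compound 3 (within the scatter) stays within the scatter, with no clear direction. For compound 3 the estimated inhibition is 38%, with a likely range from 20% to 56%.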

Compound 3, a percentage reported as inhibition, at one concentration (the size of the read-out at that concentration, not a potency): 40%
Compound 3: the middle estimate sits 2 percentage points below what was measured, within the range that was stated.
By their numbers in this assay, from the lowest: compounds 1, 2 and 3 (each within the scatter of the next).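

Among these compounds, compound 2 and compound 3 form the first pair here that differs in one place only, and in this assay the step reads no change at the digits printed from compound 2 to compound 3 (within the scatter) for this exchange. On this carbon of the six-membered aromatic ring, hydrogen in place of methyl therefore leaves the inhibition at the concentration tested level within the scatter, something compound 1 and compound 2 could not show, as they differ in two places at once. Nothing available here offers an explanation for this result. From the compounds shown here alone, whether an ethyl chain, a methoxy group or an amine on this same carbon would hold that level remains open. So does whether a single change elsewhere on the shared core would move the number, and a reading at one concentration does not give a potency.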